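Methyl to ethyl on the cyclopentyl compound

This account rests on a few compounds, and the source may have more. Where it says the series, first, only, none or still open, it means among the compounds named here.

So far compound 1 (`Cc1cc(CN(CC2CC2)[C@@H](CC(=O)O)c2ccc(Cl)cc2)ccc1OCCN1C(=O)CCC1=O`) and compound 2 (`Cc1cc(CN(CC2CCCC2)[C@@H](CC(=O)O)c2ccc(Cl)cc2)ccc1OCCN1C(=O)CCC1=O`) have been measured. In an ADME assay on liver (Mus musculus) for metabolic stability, read by LC-MS, using microsomes and NADPH (a lower number here means that less of the compound is left, a higher number that more of the compound is left), compound 1 gives 87% and compound 2 gives 69%, so compound 2 holds the lower of the two numbers. Among the measured compounds shown here, the only measured step is a number 18 percentage points lower from compound 1 to compound 2 (beyond the scatter), and it lies beyond the scatter. It places cyclopentyl in the position of cyclopropyl on a saturated chain carbon bound to an amine nitrogen.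

Compound 3 (`CCc1cc(CN(CC2CCCC2)[C@@H](CC(=O)O)c2ccc(Cl)cc2)ccc1OCCN1C(=O)CCC1=O`) keeps the cyclopentyl group of compound 2. The change is methyl in place of hydrogen on a saturated chain carbon bound to an aromatic carbon, with methyl in place of hydrogen on a saturated chain carbon bound to an aromatic carbon, which turns methyl into ethyl. For the measured compounds named here, no measured pair covers this change, and the one available step lies at another place in the structure, so it serves only as a rough guide to size. On that guide, a number 18 percentage points lower from compound 1 to compound 2 (beyond the scatter), a smaller downward move is expected, and it may stay within the scatter. The expected step is a number 7 percentage points lower from compound 2 to compound 3 (within the scatter). For compound 3 the estimated value is 62%, with an expected range of 45% to 78%.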

Compound 3, percent of the compound remaining: 27%
The estimate for compound 3 lay 35 percentage points above the measured number; the measured number lies below the stated range.
By their numbers in this assay, from the lowest: compound 3; then compound 2; then compound 1.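

In this assay, the single added methyl that turns methyl into ethyl gives a number 42 percentage points lower from compound 2 to compound 3 (beyond the scatter), so this place on a saturated chain carbon bound to an aromatic carbon is highly sensitive to the change, even though it adds only one heavy atom. Of the two steps now available, this is the large one, whereas a number 18 percentage points lower from compound 1 to compound 2 (beyond the scatter) at the cyclopentyl place is modest, so the ethyl change moves the percent remaining further than the ring change did. Nothing available bears on the reason for this drop.

Going by these compounds, the ethyl step is known only on the cyclopentyl compound, so it remains open whether ethyl would lower the number as far with cyclopropyl in the other position, and whether the two changes simply add up. On these data alone, it is also open whether a longer chain such as propyl would continue the fall, or whether a different small group at this place, such as methoxy or a chlorine atom, would keep the number nearer that of compound 2 at 69%.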